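Three Aryl Variants Point Toward a Fourth

The source may hold more compounds than are shown below. What is called first, only, known or untested is meant among the compounds shown, and "the series" means these compounds.

Compound 1, `COc1cc(-n2cnc3ccc(-c4ccc(C)cc4F)cc32)cc(OC)c1OC`, gives 5650 nM in a functional assay on SGC-7901 cells (Homo sapiens) for antiproliferative activity, read by MTT assay, with a stated time of 72 h; a lower number here means a stronger inhibitor, a higher number a weaker inhibitor.
Compound 2, `COc1ccc(-c2ccc3ncn(-c4cc(OC)c(OC)c(OC)c4)c3c2)cc1F`, gives 430 nM in this assay.
Compound 3, `COc1cc(-n2cnc3ccc(-c4cc(F)ccc4F)cc32)cc(OC)c1OC`, gives 6590 nM in this assay.

Among these three, compound 1 holds the second highest number. Its nearest neighbour is compound 3, reached by a 1.2-fold higher number from compound 1 to compound 3 (0.07 log units; within the scatter), a step that does not rise above the usual scatter. Its furthest neighbour is compound 2, reached by a 13-fold lower number from compound 1 to compound 2 (1.12 log units; beyond the scatter), a large step. The remaining pair shows a 15-fold higher number from compound 2 to compound 3 (1.19 log units; beyond the scatter), again large.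

The unmeasured compound 4, `COc1cc(-n2cnc3ccc(-c4ccc(Cl)cc4)cc32)cc(OC)c1OC`, differs from compound 1 in one place: 4-chlorophenyl in place of 2-fluoro-4-methylphenyl on an aromatic carbon. For the measured compounds named here, no measured step introduces a 4-chlorophenyl, so the expectation rests on the two steps that leave compound 1. Swapping the aryl group has produced one small change and one large one, so the outcome for compound 4 is open in either direction. Compound 4 is expected to land between the two measured extremes, with a modest improvement corresponding to a 2.8-fold lower number from compound 1 to compound 4 (0.45 log units; beyond the scatter). The estimated value for compound 4 in this assay is 2000 nM, within a range from 500 nM to 8000 nM.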

Compound 4, half-maximal inhibitory concentration: 1270 nM
Beside the measured number, compound 4's estimate is 1.6-fold (0.20 log units) above it; the measured number falls inside the stated range.
By their numbers in this assay, from the lowest: compound 2; then compound 4; then compounds 1 and 3 (each within the scatter of the next).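

In this assay, replacing the 2-fluoro-4-methylphenyl of compound 1 with 4-chlorophenyl gives a clear gain (a 4.4-fold lower number from compound 1 to compound 4 (0.65 log units; beyond the scatter)), and replacing the 2,5-difluorophenyl of compound 3 gives one of similar size (a 5.2-fold lower number from compound 3 to compound 4 (0.72 log units; beyond the scatter)). The earlier compounds shown here showed a gain beyond the scatter only with the 3-fluoro-4-methoxyphenyl of compound 2, so compound 4 shows that this position can also gain with an aryl group carrying neither fluorine nor methoxy, though compound 2 still keeps the lower number (a 3.0-fold higher number from compound 2 to compound 4 (0.47 log units; beyond the scatter)). These three steps therefore place compound 4 at an intermediate level, and no measurement here accounts for the differences among the aryl groups.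

The step from compound 1 to compound 4 removes the fluorine and the methyl and introduces the chlorine all at once, so the share of each change in the gain stays unresolved. Going by these compounds, it also remains open how this position would respond to an aryl group bearing an amine or a carboxylic acid, and whether any such group could match or pass the 3-fluoro-4-methoxyphenyl of compound 2.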